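The compounds below may be only part of what the source reports. "The series", "measured", "known", "first", "only" and "open" are said of these compounds alone.

Measured so far:
compound 1 `O=C(Nc1ccccc1C(F)(F)F)C1CCc2ccccc2N1C(=O)c1ccccc1` — 8120 nM
compound 2 `O=C(Nc1ccccc1C(F)(F)F)C1CCc2ccccc2N1C(=O)c1ccc(Cl)cc1` — 551 nM
compound 3 `O=C(Nc1cc(C(F)(F)F)cc(C(F)(F)F)c1)C1CCc2ccccc2N1C(=O)c1ccccc1` — 1680 nM

All three numbers come from a functional assay on NUGC-3 cells (Homo sapiens) for cytotoxicity, read by sulforhodamine B assay, with a stated time of 72 h; a higher number here means a weaker inhibitor of growth, a lower number a stronger inhibitor of growth. Between compound 1 and compound 2 the only change is chloro in place of hydrogen on an aromatic carbon, and it gave a 15-fold lower number from compound 1 to compound 2 (1.17 log units; beyond the scatter). Compound 4 `O=C(Nc1cc(C(F)(F)F)cc(C(F)(F)F)c1)C1CCc2ccccc2N1C(=O)c1cccc(Cl)c1` has not yet been run; it differs from compound 3 by chloro in place of hydrogen on an aromatic carbon. The difference between the cores of compound 1 and compound 3 is not broken down here. The two chloro entries are the same kind of change, not the same: in compound 2 the chloro stands para to a large group, in compound 4 meta to a large group. In this assay, going by the values given here, a step of a 4.2-fold lower number from compound 3 to compound 4 (0.62 log units; beyond the scatter) is expected, resting on a 15-fold lower number from compound 1 to compound 2 (1.17 log units; beyond the scatter) but taken smaller since the place differs and only one such step is known. Compound 4 is estimated at 400 nM, plausibly between 120 nM and 1500 nM.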

Compound 4, concentration for 50% growth inhibition: 560 nM
Beside the measured number, compound 4's estimate is 1.4-fold (0.15 log units) below it; the measured number falls inside the stated range.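

In this assay, chloro in place of hydrogen on an aromatic carbon again lowers the number, a 3.0-fold lower number from compound 3 to compound 4 (0.48 log units; beyond the scatter), so the direction of the change holds on both cores shown. The size does not carry over: the same change on two cores in this assay, a 15-fold lower number (1.17 log units; beyond the scatter) from compound 1 to compound 2 and a 3.0-fold lower number (0.48 log units; beyond the scatter) from compound 3 to compound 4, 4.9-fold (0.69 log units) apart, beyond the scatter of two such steps The chloro of compound 4 stands meta to a large group and the earlier chloro does not, so the two steps differ in place as well as in core, and the gap cannot be assigned to either difference; two steps also make no general rule for the series.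

Open, as far as these compounds go, is how a single core responds to chloro at both places. Also open, from the compounds shown here alone, is whether a methoxy group or an amine in place of the chloro lowers the number as well.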